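Furan to thiophene swap at the aromatic carbon

A few compounds are considered here, and "the series" means these few. Any claim that something is new, unique, unknown or untested is made for them only; others in the source may bear on it.

Measured so far in a functional assay on A-375 cells (Homo sapiens) for antiproliferative activity, read by trypan blue exclusion and crystal violet staining, with a stated time of 72 h (on this read-out higher numbers stand for weaker inhibition and lower numbers for stronger inhibition), and no other test:
- compound 1 `CC1(C)CC(NC(=O)c2cnn3c(C(F)F)cc(C4CC4)nc23)c2ccccc2O1` at 2200 nM
- compound 2 `O=C(NC1CCCc2ccccc21)c1cnn2c(C(F)(F)F)cc(-c3ccco3)nc12` at 600 nM

Of these two numbers, compound 2 at 600 nM has the lower, and so the stronger inhibition, with compound 1 at 2200 nM higher by more than the usual scatter. The two compounds differ in more than one place, so their gap isolates no single change.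

Compound 3 `O=C(NC1CCCc2ccccc21)c1cnn2c(C(F)(F)F)cc(-c3cccs3)nc12` is still unmeasured. It has thiophen-2-yl in place of furan-2-yl on an aromatic carbon and keeps the rest of compound 2 unchanged. Going by the values given here, no measured pair shows this swap, so the only anchor is compound 2 at 600 nM in this assay and the expectation rests on the close match of the two rings in what is counted. No step beyond the scatter is expected, in either direction.

The estimated step is a 1.1-fold higher number from compound 2 to compound 3 (0.03 log units; within the scatter) and is expected to stay within the scatter.

Compound 3 is estimated at 650 nM with an expected range of 250 nM to 1700 nM in this test.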

Compound 3, half-maximal inhibitory concentration: 1200 nM
For compound 3 the middle estimate is 1.8-fold (0.27 log units) below the measured one; the measured number falls inside the stated range.
By their numbers in this assay, from the lowest: compounds 2, 3 and 1 (each within the scatter of the next, the first and the last beyond it).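

In this assay, going by these compounds alone, thiophen-2-yl in place of furan-2-yl on the aromatic carbon next to the ring nitrogen gives a 2.0-fold higher number from compound 2 to compound 3 (0.30 log units; within the scatter), and this is the first comparison that isolates a single change. At this position, the oxygen-containing and sulfur-containing five-membered aromatic rings therefore cannot be told apart, and neither ring can be preferred on this read-out. No measurement at hand accounts for the result.

The compounds shown leave open whether this position accepts anything other than a five-membered aromatic ring with one hetero atom, such as phenyl, pyridin-2-yl or morpholine, since the cyclopropyl of compound 1 comes together with changes elsewhere in the molecule. Also open, going by these compounds, is what the trifluoromethyl group and the amide substituent each contribute on their own, since compound 1 differs from compound 2 and compound 3 in more than one place and its gap to them isolates neither.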